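The compounds below may be only part of what the source reports. "The series", "measured", "known", "first", "only" and "open" are said of these compounds alone.

In a functional assay on LoVo cells (Homo sapiens) for antiproliferative activity, read by MTT assay, with a stated time of 72 h (on this read-out higher numbers stand for weaker inhibition of growth and lower numbers for stronger inhibition of growth), compound 1 (`CC(=O)Nc1cc(=O)n(CC(C)C)c(SCc2ccccc2)n1`) gives 58500 nM. Compound 2 (`Cc1ccc2nc(-c3ccc([N+](=O)[O-])cc3)cn2c1`) gives > 100000 nM, which is a limit of the assay and not a number, so it stands at the limit of > 100000 nM in this assay, at which 1 of the 2 values shown sits. Compound 3 (`Cc1ccc2nc(-c3ccc(NCc4ccccc4)cc3)cn2c1`) has benzylamino in place of nitro on an aromatic carbon, para to a large group: benzylamino in place of nitro on an aromatic carbon. Going by the values given here, no measured pair here shows a change of this kind, so the expectation in this assay is loose. A modest move towards stronger inhibition of growth is expected, and the read-out may well stay at the limit. The expected size of the change is an at least 2.8-fold lower number from compound 2 to compound 3 (0.45 log units; beyond the scatter), an estimate made against a limit and not against a number. For compound 3 the estimated value is 35000 nM, with an expected range from 8000 nM to 100000 nM.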

Compound 3, concentration for 50% growth inhibition: 42600 nM
Compound 3: the middle estimate sits 1.2-fold (0.09 log units) below what was measured, within the range that was stated.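

In this assay, benzylamino in place of nitro on an aromatic carbon, para to a large group, gives an at least 2.3-fold lower number from compound 2 to compound 3 (0.37 log units; beyond the scatter). Going by these compounds alone, this is the first readable step in the set, and it shows that this position responds to a change of group, with compound 3 giving a measured number where compound 2 gives only a limit. The full size of the step remains unknown because compound 2 stands at that limit: the limit of > 100000 nM in this assay, at which 1 of the 3 values shown sits.

The compounds shown leave open whether the step belongs to the nitrogen on the aromatic ring or to the added benzyl part, which a simple amine or an acetamide at the same place would help to separate. They also leave open how a longer chain between that nitrogen and the outer aromatic ring, or a carboxylic acid on that ring, would read out.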